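The compounds below may be only part of what the source reports. "The series", "measured", "known", "first", "only" and "open" are said of these compounds alone.

Values in a functional assay on B16-F10 cells (Mus musculus) for inhibition, read by colorimetric assay and MTT assay, with a stated time of 72 h; on this read-out higher numbers stand for weaker inhibition and lower numbers for stronger inhibition:
- compound 1 `C/C1=C\CC[C@@]2(C)O[C@@H]2[C@H]2OC(=O)[C@@H](CN3CCCC3)[C@@H]2C[C@H]1O`: 4000 nM
- compound 2 `C/C1=C\CC[C@@]2(C)O[C@@H]2[C@H]2OC(=O)[C@@H](CN3CCCCC3)[C@@H]2C[C@H]1O`: 4000 nM
- compound 3 `C/C1=C\CC[C@@]2(C)O[C@@H]2[C@H]2OC(=O)[C@@H](CN3CCN(C)CC3)[C@@H]2C[C@H]1O`: 25000 nM

Compound 3 has the highest number of the three, 25000 nM, and so the weakest inhibition in this set. Compound 4 `C/C1=C\CC[C@@]2(C)O[C@@H]2[C@H]2OC(=O)[C@@H](CN(C)CCN(C)C)[C@@H]2C[C@H]1O` replaces its ring with an open chain: (2-(dimethylamino)ethyl)(methyl)amino in place of 4-methylpiperazin-1-yl on a saturated chain carbon bound to a saturated ring carbon.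

Among the measured compounds shown here, three measured steps bear on this. The two steps into the 4-methylpiperazin-1-yl group are modest: a 6.3-fold higher number from compound 1 to compound 3 (0.80 log units; beyond the scatter), and a 6.3-fold higher number from compound 2 to compound 3 (0.80 log units; beyond the scatter). Changing the ring in the other pair gives no change at the digits printed from compound 1 to compound 2 (within the scatter). None of these steps opens a ring, so the data hold no direct measure of the change to compound 4. The groups in compound 3 and compound 4 match in the counts given, which makes compound 3, at 25000 nM, the natural reference.

The step expected in this assay is a 1.7-fold lower number from compound 3 to compound 4 (0.22 log units; within the scatter), with none clearly beyond the scatter. For compound 4 the estimated value is 15000 nM, with an expected range of 5000 nM to 40000 nM.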

Compound 4, half-maximal inhibitory concentration: 4000 nM
Beside the measured number, compound 4's estimate is 3.8-fold (0.57 log units) above it; measured number below the stated range.
By their numbers in this assay, from the lowest: compounds 1, 2 and 4 (each within the scatter of the next); then compound 3.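

In this assay the open chain (2-(dimethylamino)ethyl)(methyl)amino in place of 4-methylpiperazin-1-yl gives a 6.3-fold lower number from compound 3 to compound 4 (0.80 log units; beyond the scatter) (the two groups match in every count given), so the higher number of compound 3 does not follow from those counts. The open chain also falls level with both simple rings, with no change at the digits printed from compound 2 to compound 4 (within the scatter) and no change at the digits printed from compound 1 to compound 4 (within the scatter), which leaves compound 3 as the only one of the four that stands apart at this position. No measurement shown accounts for the gap between compound 3 and compound 4.

Open, as far as these compounds go, is whether the higher number belongs to the 4-methylpiperazin-1-yl ring alone, which a morpholin-4-yl or an unsubstituted piperazin-1-yl group at this position would test. Also open, from the compounds shown here alone, is how a longer chain, such as (3-(dimethylamino)propyl)(methyl)amino, would read.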